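From Hydrogen to Methoxy in Compound 3

A few compounds are considered here, and "the series" means these few. Any claim that something is new, unique, unknown or untested is made for them only; others in the source may bear on it.

In a functional assay on L1210 cells (Mus musculus) for antiproliferative activity, read by cell counting, with a stated time of 96 h (on this read-out lower numbers stand for stronger inhibition and higher numbers for weaker inhibition), compound 1 `CC(=O)c1ccc(Oc2ccccc2NC(C)=C2C(=O)CC(c3ccccc3)CC2=O)cc1` gives 190 nM and compound 2 `CC(Nc1ccccc1Oc1ccccc1)=C1C(=O)CC(c2ccccc2)CC1=O` gives 86 nM, the lower of the two numbers. Compound 3 `COc1cccc(Oc2ccccc2NC(C)=C2C(=O)CC(c3ccccc3)CC2=O)c1` has methoxy in place of hydrogen on an aromatic carbon, meta to a large group, turning phenoxy into 3-methoxyphenoxy: methoxy in place of hydrogen on an aromatic carbon. Among the compounds with values here, the only measured step that bears on this is a 2.2-fold lower number from compound 1 to compound 2 (0.34 log units; beyond the scatter), where hydrogen replaces acetyl. Acetyl is not methoxy, so this is a loose guide, but it suggests a modest rise when hydrogen is replaced. The expected change is a 1.5-fold higher number from compound 2 to compound 3 (0.18 log units; within the scatter). For compound 3 the estimated value is 130 nM, with an expected range of 60 nM to 280 nM.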

Compound 3, half-maximal inhibitory concentration: 58 nM
Beside the measured number, compound 3's estimate is 2.2-fold (0.35 log units) above it; the whole stated range lies above it.
By their numbers in this assay, from the lowest: compounds 3 and 2 (each within the scatter of the next); then compound 1.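

In this assay, methoxy in place of hydrogen on this aromatic carbon, meta to a large group, gives a 1.5-fold lower number from compound 2 to compound 3 (0.17 log units; within the scatter), so this position accepts methoxy with no change beyond the scatter. Against the 4-acetylphenyl of compound 1, the 3-methoxyphenyl group gives a 3.3-fold lower number from compound 1 to compound 3 (0.52 log units; beyond the scatter), a modest step beyond the scatter. No evidence at hand gives a reason for either step. As far as these compounds go, whether an amine or a carboxylic acid on the same carbon would be accepted stays open, as does the outcome with a longer chain such as ethoxy.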